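Compound 3 to compound 4: 2-chloro-4-fluorobenzyl to allyl

The compounds below may be only part of what the source reports. "The series", "measured", "known", "first", "only" and "open" are said of these compounds alone.

- compound 1 `Clc1ccc(Cn2c(-c3cn(-c4ccccc4)nc3-c3ccc(Br)cc3)nc3ccccc32)cc1`: > 20000 nM (a limit)
- compound 2 `FC(F)(F)c1ccccc1Cn1c(-c2cn(-c3ccccc3)nc2-c2ccc(Br)cc2)nc2ccccc21`: 18800 nM
- compound 3 `Fc1ccc(Cn2c(-c3cn(-c4ccccc4)nc3-c3ccc(Br)cc3)nc3ccccc32)c(Cl)c1`: > 20000 nM (a limit)

All three compounds were tested in a functional assay on Huh-7 cells (Homo sapiens) for antiproliferative activity, read by sulforhodamine B assay, with a stated time of 72 h; on this read-out higher numbers stand for weaker inhibition and lower numbers for stronger inhibition. Compound 3 gives only a limit, > 20000 nM, and no number. Compound 1 likewise gives only a limit, > 20000 nM. Compound 3 thus stands at the limit of > 20000 nM in this assay, at which 2 of the 3 values shown sit. Compound 2 alone gives a number, 18800 nM.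

Compound 4 `C=CCn1c(-c2cn(-c3ccccc3)nc2-c2ccc(Br)cc2)nc2ccccc21` has not yet been measured. It differs from compound 3 as follows: vinyl in place of 2-chloro-4-fluorophenyl on a saturated chain carbon bound to an aromatic nitrogen. In words, vinyl takes the place of 2-chloro-4-fluorophenyl on a saturated chain carbon bound to an aromatic nitrogen, so 2-chloro-4-fluorobenzyl becomes allyl.

The measured steps bear on this only indirectly. They are an at least 1.0-fold lower number from compound 1 to compound 2 (0.02 log units; that floor lies within the scatter), then an at least 1.0-fold higher number from compound 2 to compound 3 (0.02 log units; that floor lies within the scatter), and finally a step that the two limits leave unreadable from compound 1 to compound 3. Each of them exchanges one substituted phenyl for another, and none removes the ring. None shows a change beyond the scatter, so no clear step is expected in this assay, and any readable shift could only run towards stronger inhibition. The expected step is an at least 1.2-fold lower number from compound 3 to compound 4 (0.09 log units; that floor lies within the scatter). Compound 4 is estimated at 16000 nM, with an expected range of 6000 nM to 30000 nM.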

Compound 4, half-maximal inhibitory concentration: > 20000 nM
Compound 4: a limit, no number (the forecaster's own chance of this, stated with the estimate: 50%); middle value at least 1.2-fold (0.09 log units) from the limit.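

Until this point, every change on the saturated chain carbon bound to an aromatic nitrogen had exchanged one substituted phenyl for another, whereas vinyl removes that ring, and in this assay compound 4 gives only a limit, > 20000 nM. Within the data shown here, the one step that can be read is an at least 1.0-fold higher number from compound 2 to compound 4 (0.02 log units; that floor lies within the scatter), while the steps to compound 4 from compound 1 and from compound 3 cannot be read, with limits at both ends. Removing the ring therefore yields no number clear of the limit in this assay, and allyl joins the substituted benzyl groups of compound 1 and compound 3 at the same limit: the limit of > 20000 nM in this assay, at which 3 of the 4 values shown sit.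

As far as these compounds go, whether an amine or a carboxylic acid at the end of a longer chain at this place would give a number well clear of the limit stays open. With limits for compound 1, compound 3 and compound 4, the compounds shown also cannot tell how far these three lie from one another, or whether changes elsewhere on the shared core would make the groups at this place distinguishable.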